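Anilino ring: methyl to fluoro on the pendant aryl

This account rests on a few compounds, and the source may have more. Where it says the series, first, only, none or still open, it means among the compounds named here.

Three compounds of the shared core have numbers in a functional assay on U2OS cells (Homo sapiens) for antiproliferative activity, read by MTT assay, with a stated time of 72 h; a higher number here means a weaker inhibitor, a lower number a stronger inhibitor. Compound 1 `CCCCCOC1=C(C(=O)c2ccccc2)C(c2ccc(Br)cc2)N(CCCn2ccnc2)C1=O` gives 9140 nM. Compound 2 `NC1=C(C(=O)c2ccccc2)C(c2ccc(Br)cc2)N(CCCn2ccnc2)C1=O` gives 149000 nM. Compound 3 `Cc1ccc(NC2=C(C(=O)c3ccccc3)C(c3ccc(Br)cc3)N(CCCn3ccnc3)C2=O)cc1` gives 24100 nM, the second highest of the three numbers; it stands nearest compound 1 and furthest from compound 2. The steps between them are a 16-fold higher number from compound 1 to compound 2 (1.21 log units; beyond the scatter), a 2.6-fold higher number from compound 1 to compound 3 (0.42 log units; beyond the scatter) and a 6.2-fold lower number from compound 2 to compound 3 (0.79 log units; beyond the scatter).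

Compound 4 `O=C(C1=C(Nc2ccc(F)cc2)C(=O)N(CCCn2ccnc2)C1c1ccc(Br)cc1)c1ccccc1` differs from compound 3 by fluoro in place of methyl on an aromatic carbon. Among the measured compounds shown here, no measured step touches a substituent on the anilino ring itself. The closest comparisons are a 6.2-fold lower number from compound 2 to compound 3 (0.79 log units; beyond the scatter), where the whole aryl group replaces hydrogen on the amine nitrogen, and a 2.6-fold higher number from compound 1 to compound 3 (0.42 log units; beyond the scatter), where the anilino group replaces pentyloxy; both are modest. A swap of one small substituent for another on the aryl ring, with no change in donors, acceptors or charge, is expected to move the number less than either of those steps. The expected step is a 1.0-fold higher number from compound 3 to compound 4 (0.02 log units; within the scatter), within the usual scatter. Compound 4 is therefore estimated at 25000 nM in this assay, with a range from 8000 nM to 80000 nM.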

Compound 4, half-maximal inhibitory concentration: 30000 nM
Estimate against measurement, compound 4: 1.2-fold (0.08 log units) below, within the range that was stated.
By their numbers in this assay, from the lowest: compound 1; then compounds 3 and 4 (each within the scatter of the next); then compound 2.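

In this assay, among the compounds shown here, the anilino ring itself is varied for the first time, and a 1.2-fold higher number from compound 3 to compound 4 (0.10 log units; within the scatter) shows that this position, para to a large group, tolerates fluoro in place of methyl with no change that can be read. The earlier comparison with the free amino compound holds with the new substituent, as a 5.0-fold lower number from compound 2 to compound 4 (0.70 log units; beyond the scatter) shows the 4-fluorophenyl group again separating from hydrogen on the amine nitrogen by a step beyond the scatter. The pentyloxy compound also stays apart from the anilino compounds, with a 3.3-fold higher number from compound 1 to compound 4 (0.52 log units; beyond the scatter) alongside a 2.6-fold higher number from compound 1 to compound 3 (0.42 log units; beyond the scatter) on the methyl side, and no measurement in hand offers a reason for any of these steps.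

Methyl and fluoro are the only two groups shown on the anilino ring, so how it responds to a carboxylic acid, a dimethylamino group or a longer alkoxy chain at that position remains open. Also open, from the compounds shown here alone, is whether the aryl ring is needed on the amine nitrogen at all, which a pentylamino chain in its place would test directly against the pentyloxy compound.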